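The source may report more compounds than this note shows. Statements on the series, on what has been measured and on what is new or still open speak of the compounds shown alone.

Three compounds have values in a functional assay on HeLa cells (Homo sapiens) for antiproliferative activity, read by resazurin assay (a higher number here means a weaker inhibitor, a lower number a stronger inhibitor), so far: compound 1 (`O=C(CSC(=S)Sc1ccccc1)c1ccc(Cl)c(Cl)c1`) at 20000 nM and compound 2 (`CC(C)SC(=S)SCC(=O)c1ccc(Cl)c(Cl)c1`) at 25100 nM and compound 3 (`CCSC(=S)SCC(=O)c1ccc(S(N)(=O)=O)cc1`) at 20000 nM as well. Compound 2 therefore stands within the scatter of both others. Compound 4 (`CC(C)(C)SC(=S)SCC(=O)c1ccc(Cl)c(Cl)c1`) differs from compound 2 in one place (methyl in place of hydrogen on a saturated chain carbon bound to two saturated chain carbons and a sulfur) which turns isopropyl into tert-butyl. For the measured compounds named here, the one measured step that bears on this also changes the group on a sulfur, isopropyl in place of phenyl (a 1.3-fold higher number from compound 1 to compound 2 (0.10 log units; within the scatter)) and it stays within the scatter. Going by the values given here, with that step as the only guide, no step beyond the scatter is expected in this assay for this change. The expected step is small (a 1.1-fold lower number from compound 2 to compound 4 (0.06 log units; within the scatter)) and lies within the scatter. Compound 4 is estimated at 22000 nM and expected to fall between 10000 nM and 50000 nM on repeated measurement.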

Compound 4, half-maximal inhibitory concentration: 10000 nM
The estimate for compound 4 lay 2.2-fold (0.34 log units) above the measured number, and the stated range covers the measured number.
By their numbers in this assay, from the lowest: compounds 4, 1, 3 and 2 (each within the scatter of the next, the first and the last beyond it).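

Turning isopropyl into tert-butyl on this sulfur gives the first step beyond the scatter in this assay (a 2.5-fold lower number from compound 2 to compound 4 (0.40 log units; beyond the scatter)), so one added methyl at this saturated chain carbon can move the number, if only modestly. Tert-butyl in place of phenyl on the same sulfur stays within the scatter (a 2.0-fold lower number from compound 1 to compound 4 (0.30 log units; within the scatter)). Nothing measured here explains the shift.

The compounds shown leave open whether a longer chain or a cyclohexyl ring on this sulfur would move the number further. From the compounds shown here alone, whether the same change holds on the core of compound 3 also remains open.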